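Pyridin-2-yl in place of oxolan-3-yl: compound 3 to compound 4

The source may hold more compounds than are shown below. What is called first, only, known or untested is meant among the compounds shown, and "the series" means these compounds.

Measured so far in an ADME assay on MT4 cells (Homo sapiens) for cytotoxicity, with a stated time of 5 days; a lower number here means that less compound is tolerated, a higher number that more compound is tolerated:
compound 1 `CC(C)N(c1cc(C#CC(C)(C)C)sc1C(=O)O)C(=O)[C@H]1CC[C@H](C)CC1` gives > 20000 nM
compound 2 `CC(C)(C)C#Cc1cc(N(C(=O)[C@H]2CC[C@H](C)CC2)[C@H]2CC[C@H](OC3CCOCC3)CC2)c(C(=O)O)s1` gives > 20000 nM
compound 3 `CC(C)(C)C#Cc1cc(N(C(=O)[C@H]2CC[C@H](C)CC2)[C@H]2CC[C@H](OC3CCOC3)CC2)c(C(=O)O)s1` gives > 20000 nM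

Each of these entries is a limit of the assay and not a number. Compound 3 stands at > 20000 nM as a limit, and the whole series reads the same way: the limit of > 20000 nM in this assay, at which 3 of the 3 values shown sit.

Compound 4 `CC(C)(C)C#Cc1cc(N(C(=O)[C@H]2CC[C@H](C)CC2)[C@H]2CC[C@H](Oc3ccccn3)CC2)c(C(=O)O)s1` is still to be measured. It carries pyridin-2-yl in place of oxolan-3-yl on an oxygen on a saturated carbon and has the rest of compound 3 unchanged.

Within the data shown here, two measured steps bear on this change. The closer one is a step that the two limits leave unreadable from compound 2 to compound 3, made at the same place. The other is a step that the two limits leave unreadable from compound 1 to compound 3, made on the amide-type nitrogen. Among the measured compounds shown here, neither gives a size to carry over, and no measured compound holds pyridin-2-yl. No step beyond the scatter is therefore expected in this assay, and a further limit reading is the likeliest outcome. The expected change is a number no higher from compound 3 to compound 4 (the limit leaves the size open) as an estimate. For compound 4 the estimated value is 20000 nM, with an expected range from 10000 nM to 40000 nM.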

Compound 4, half-maximal cytotoxic concentration: > 20000 nM
Compound 4 ended at the assay's limit; the forecaster's own chance of this, stated with the estimate: 80%; the middle value lies on the limit itself.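

In this assay compound 4 gives > 20000 nM, a limit of the assay. No step from compound 2 or compound 3 to compound 4 can be read, and the series stays at one reading: the limit of > 20000 nM in this assay, at which 4 of the 4 values shown sit.

The compounds shown leave open where any of them would read in this assay, and whether pyridin-2-yl, oxolan-3-yl and oxan-4-yl differ there at all.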